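This account rests on a few compounds, and the source may have more. Where it says the series, first, only, none or still open, it means among the compounds named here.

Within the data shown here, compound 1 `O=C(c1ccn2c1CSC2c1cccnc1)c1c[nH]c2cc(-c3ccc(F)cc3)ccc12` is one of two compounds measured here in a functional assay (Oryctolagus cuniculus) for antagonist activity at platelet-activating factor receptor (Cavia porcellus); a higher number here means a weaker inhibitor, a lower number a stronger inhibitor. In that assay compound 1 gives 75 nM, the lower of the two numbers, while compound 2 `CC(C)(C)OC(=O)n1cc(C(=O)c2ccn3c2CSC3c2cccnc2)c2ccccc21` gives 110 nM in this assay, a difference that falls within the usual scatter, so the two cannot be ranked against each other. Compound 2 carries a large group on the aromatic nitrogen of the shared core and lacks the fluorophenyl of compound 1, yet its number sits close to that of compound 1, which suggests that a substituent on that nitrogen is tolerated.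

Compound 3 `CCNC(=O)n1cc(C(=O)c2ccn3c2CSC3c2cccnc2)c2ccc(-c3ccc(F)cc3)cc21` has not yet been measured. It differs from compound 1 as follows: ethylcarbamoyl in place of hydrogen on an aromatic nitrogen. Given that compound 2, with its own group on the same aromatic nitrogen, gives 110 nM, no step beyond the scatter is expected from compound 1 to compound 3 in this assay. Compound 3 is therefore expected to give about 70 nM, with a range from 25 nM to 200 nM, and the estimated step is a 1.1-fold lower number from compound 1 to compound 3 (0.03 log units; within the scatter).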

Compound 3, inhibition constant: 19 nM
For compound 3 the middle estimate is 3.7-fold (0.57 log units) above the measured one, and the stated range ends above it.
By their numbers in this assay, from the lowest: compound 3; then compounds 1 and 2 (each within the scatter of the next).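

With the fluorophenyl group kept, the ethylcarbamoyl group on the aromatic nitrogen is more than tolerated in this assay: the change gives a 3.9-fold lower number from compound 1 to compound 3 (0.60 log units; beyond the scatter) and this step lies beyond the scatter, though it remains modest. Compound 1 and compound 3 differ in this one place alone, so this pair gives a direct reading of a substituent at this position, which compound 2 could not give, as it differs from compound 1 in more than one place. No measurement shown here accounts for the step.

This single pair does not separate the contributions of the ethyl part, the carbonyl and the amide hydrogen, and it leaves open whether a methylcarbamoyl, an acetyl or a longer chain such as butylcarbamoyl would give a similar number. It also leaves open how a terminal amine or carboxylic acid on that chain would read in this assay, and whether the ethylcarbamoyl group would give a similar step on a core without the fluorophenyl group.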